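Shortening the carbamate chain of a selenocyanate

A few compounds are considered here, and "the series" means these few. Any claim that something is new, unique, unknown or untested is made for them only; others in the source may bear on it.

Three compounds were tested in a functional assay on HTB-54 cells (Homo sapiens) for cytotoxicity, read by MTT assay, with a stated time of 72 h; on this read-out lower numbers stand for stronger inhibition of growth and higher numbers for weaker inhibition of growth. Compound 1 `N#C[Se]c1ccc(NC(=O)OCc2ccc([N+](=O)[O-])cc2)cc1` gives 47600 nM in this assay. Compound 2 `CC(C)COC(=O)Nc1ccc([Se][Se]c2ccc(NC(=O)OCC(C)C)cc2)cc1` gives 52900 nM in this assay. Compound 3 `CCCOC(=O)Nc1ccc([Se]C#N)cc1` gives 51900 nM in this assay. Among these three numbers compound 3 stands second highest, but its nearest neighbour, compound 2, and its furthest neighbour, compound 1, both lie within the usual scatter of repeated measurements, so the three values cannot be told apart.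

Compound 4 `CCOC(=O)Nc1ccc([Se]C#N)cc1` has not yet been measured in this assay. It differs from compound 3 in one place: hydrogen in place of methyl on a saturated chain carbon, two bonds along the chain from an oxygen next to a carbonyl group. The shared core of compound 3 and compound 4, with its selenocyanate and carbamate, is unchanged; only the chain on the carbamate oxygen is one carbon shorter.

Among the measured compounds shown here, no measured pair in this set shows what such a shortening does. The three measured values all sit close together despite larger differences, so the step expected from compound 3 to compound 4 is a 1.0-fold lower number from compound 3 to compound 4 (0.02 log units; within the scatter), within the scatter and in no particular direction. Compound 4 is therefore estimated to give 50000 nM in this assay, with a range from 25000 nM to 100000 nM.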

Compound 4, concentration for total growth inhibition: 49300 nM
Compound 4: middle estimate off by 1.0-fold (0.01 log units), on the high side; measured number inside the range.
By their numbers in this assay, from the lowest: compounds 1, 4, 3 and 2 (each within the scatter of the next).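

In this assay, hydrogen in place of methyl on a saturated chain carbon, two bonds along the chain from an oxygen next to a carbonyl group, gives a 1.1-fold lower number from compound 3 to compound 4 (0.02 log units; within the scatter) and so lies within the scatter. Among the compounds shown here, this is the first pair in the set that differs in one place, and it shows that propoxy and ethoxy on the shared core cannot be told apart on this read-out. No measurement offered here accounts for this result.

Going by these compounds, a single step says nothing about how the read-out responds further along this chain, so it remains open whether a longer chain, a methoxy group or a chain carrying an amine or a carboxylic acid would give a number beyond the scatter. On these data alone, it also remains open whether the same step would look alike on a core with something other than the selenocyanate.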